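The source may report more compounds than this note shows. Statements on the series, on what has been measured and on what is new or still open speak of the compounds shown alone.

The shared core appears in compound 1 `N#CC1=C(N)Oc2c(N)cc3nc4ccccc4nc3c2C12C(=O)N(Cc1cnnn1-c1ccccc1Cl)c1ccccc12`, compound 2 `N#CC1=C(N)Oc2c(N)cc3nc4ccccc4nc3c2C12C(=O)N(Cc1cnnn1-c1ccccc1Br)c1ccccc12` and compound 3 `Cc1ccc(Cl)cc1-n1nncc1CN1C(=O)C2(C(C#N)=C(N)Oc3c(N)cc4nc5ccccc5nc4c32)c2ccccc21`, which differ only in the aryl group on an aromatic nitrogen. In a functional assay on A549 cells (Homo sapiens) for antiproliferative activity, read by MTT assay, with a stated time of 48 h (on this read-out lower numbers stand for stronger inhibition and higher numbers for weaker inhibition), compound 1 gives 29800 nM. In this assay compound 2 gives 27400 nM, and the step of a 1.1-fold lower number from compound 1 to compound 2 (0.04 log units; within the scatter). For compound 3 this assay reports only a limit, > 50000 nM, so compound 3 stands at the limit of > 50000 nM in this assay, at which 1 of the 3 values shown sits, rather than at a number. The steps of an at least 1.6-fold higher number from compound 1 to compound 3 (0.22 log units; that floor lies within the scatter) and an at least 1.8-fold higher number from compound 2 to compound 3 (0.26 log units; that floor lies within the scatter) are the ones that bear on the next change. Compound 4 `N#CC1=C(N)Oc2c(N)cc3nc4ccccc4nc3c2C12C(=O)N(Cc1cnnn1-c1ccc(Cl)cc1[N+](=O)[O-])c1ccccc12` carries 4-chloro-2-nitrophenyl in place of 5-chloro-2-methylphenyl on an aromatic nitrogen. Since the earlier changes at this position gave no step beyond the scatter, compound 4 is expected to land near compound 3, the step of an at least 1.1-fold lower number from compound 3 to compound 4 (0.04 log units; that floor lies within the scatter) being expected to be small. Compound 4 is estimated at 45000 nM, between 20000 nM and 120000 nM.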

Compound 4, half-maximal inhibitory concentration: > 50000 nM
Compound 4 ended at the assay's limit (the forecaster's own chance of this, stated with the estimate: 55%); at least 1.1-fold (0.04 log units) between middle value and limit.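

With 4-chloro-2-nitrophenyl on the aromatic nitrogen, compound 4 also gives a limit rather than a number in this assay, so a second aryl group now sits there: the limit of > 50000 nM in this assay, at which 2 of the 4 values shown sit.

The readable steps are an at least 1.8-fold higher number from compound 2 to compound 4 (0.26 log units; that floor lies within the scatter) and an at least 1.6-fold higher number from compound 1 to compound 4 (0.22 log units; that floor lies within the scatter), and the step between compound 3 and compound 4 cannot be read, as both values are limits. Replacing 5-chloro-2-methylphenyl with 4-chloro-2-nitrophenyl therefore brings no measurable number back.

As far as these compounds go, whether an aryl ring carrying an amine or a carboxylic acid would give a measurable number remains open, as does how far compound 3 and compound 4 lie beyond the limit.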